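The source may hold more compounds than are shown below. What is called first, only, known or untested is meant among the compounds shown, and "the series" means these compounds.

Measured compounds:
- Compound 1, `Nc1ccc(S(=O)(=O)Nc2ccnc3cc(C(F)(F)F)ccc23)cc1`: 31000 nM
- Compound 2, `CC(=O)NS(=O)(=O)c1ccc(N/C(S)=N\c2ccnc3cc(C(F)(F)F)ccc23)cc1`: 58600 nM
- Compound 3, `Cc1cc(NS(=O)(=O)c2ccc(N/C(S)=N\c3ccnc4cc(C(F)(F)F)ccc34)cc2)on1`: 80300 nM

All three were read in a functional assay on MDA-MB-231 cells (Homo sapiens) for antiproliferative activity, read by sulforhodamine B assay, with a stated time of 48 h; on this read-out lower numbers stand for stronger inhibition and higher numbers for weaker inhibition. Compound 3 gives the highest number of the three; the nearest is compound 2, and the gap between the two is within the scatter, so no order between them can be read. Compound 1 stands further off, beyond the scatter, with the lower number.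

Compound 4, `O=S(=O)(Nc1nccs1)c1ccc(N/C(S)=N\c2ccnc3cc(C(F)(F)F)ccc23)cc1`, has not been measured. It differs from compound 3 in one place: 1,3-thiazol-2-yl in place of 3-methyl-1,2-oxazol-5-yl on a sulfonamide nitrogen. Among the compounds with values here, the only measured step that bears on this position is a 1.4-fold higher number from compound 2 to compound 3 (0.14 log units; within the scatter), an exchange of the group on the same sulfonamide nitrogen that left the number essentially unchanged. The thiourea-bearing compounds 2 and 3 both sit well above compound 1, and nothing here suggests that a further change of the group on the sulfonamide nitrogen moves the number beyond the scatter.

For compound 4 the expected result is therefore a step of a 1.2-fold lower number from compound 3 to compound 4 (0.09 log units; within the scatter), that is, no shift beyond the scatter. The estimate for compound 4 is 65000 nM, with a range from 25000 nM to 160000 nM.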

Compound 4, half-maximal inhibitory concentration: 24400 nM
For compound 4 the middle estimate is 2.7-fold (0.43 log units) above the measured one, outside the stated range (below it).
By their numbers in this assay, from the lowest: compounds 4, 1, 2 and 3 (each within the scatter of the next, the first and the last beyond it).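

In this assay the group on the sulfonamide nitrogen can move the number beyond the scatter: the change gives a 3.3-fold lower number from compound 3 to compound 4 (0.52 log units; beyond the scatter) and, against the acetyl group, a 2.4-fold lower number from compound 2 to compound 4 (0.38 log units; beyond the scatter), whereas the earlier exchange gave only a 1.4-fold higher number from compound 2 to compound 3 (0.14 log units; within the scatter). The leaving and entering groups are both five-membered aromatic rings with 2 hetero atoms and have the same hydrogen-bond donor and acceptor counts, so those counts do not separate them here. No evidence on hand explains the shift.

The compounds shown leave open whether the shift follows the ring sulfur of 1,3-thiazol-2-yl or the absence of the methyl group of 3-methyl-1,2-oxazol-5-yl. A plain 1,2-oxazol-5-yl or a 4-methyl-1,3-thiazol-2-yl group would separate these two differences, and a pyridin-2-yl group would test a six-membered ring at this position.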